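A few compounds are considered here, and "the series" means these few. Any claim that something is new, unique, unknown or untested is made for them only; others in the source may bear on it.

Measured so far:
compound 1 `COc1cc2c(cc1OC)C(CC(N)=O)CC2` — 27.8%
compound 2 `CNC(=O)CC1CCc2cc(OC)c(OC)cc21` — 24.1%

In a functional assay on the whole organism (strain Wistar) for inhibition, with Rattus norvegicus as the target, read by paw edema, with stated times of 60 min and 6 h, at a dose of 100 mg/kg by the oral route (a higher number here means more inhibition at the dose given (going by the name of the read-out), a lower number less inhibition), compound 1 gives 27.8%, and compound 2 gives 24.1%. Among the measured compounds shown here, compound 2 stands alongside compound 1 on these numbers: the one step between them, a number 3.7 percentage points lower from compound 1 to compound 2 (within the scatter), is within the scatter, so the two cannot be told apart in this assay.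

Compound 3 `CCNC(=O)CC1CCc2cc(OC)c(OC)cc21` carries the change (methyl in place of hydrogen on a saturated chain carbon bound to an amide-type nitrogen). For the measured compounds named here, only one measured step bears on it, a number 3.7 percentage points lower from compound 1 to compound 2 (within the scatter), in which methyl replaced hydrogen on the same amide-type nitrogen without a change beyond the scatter. Growing that methyl into ethyl is a change of the same kind, one saturated carbon further out, and nothing in the two measured compounds points to a step beyond the scatter in either direction in this assay.

Compound 3 is therefore expected to give 24%, with a range from 12% to 36%. The expected step is a number 0.1 percentage points lower from compound 2 to compound 3 (within the scatter), which would lie within the scatter.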

Compound 3, a percentage reported as inhibition, in the whole organism at one dose (the size of the read-out at that dose, not a potency): 20.4%
Estimate against measurement, compound 3: 3.6 percentage points above, and the stated range covers the measured number.
By their numbers in this assay, from the lowest: compounds 3, 2 and 1 (each within the scatter of the next).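

In this assay, among the compounds shown here, methyl in place of hydrogen on a saturated chain carbon bound to an amide-type nitrogen gives a number 3.7 percentage points lower from compound 2 to compound 3 (within the scatter) and so adds no step that can be told from the scatter. Ethyl in place of hydrogen on the amide-type nitrogen, the whole change taken at once, gives a number 7.4 percentage points lower from compound 1 to compound 3 (within the scatter) and thus shows that hydrogen, methyl and ethyl on that nitrogen cannot be told apart in these readings at the single dose. Nothing at hand offers an explanation for these readings.

The compounds leave open whether a longer chain on that nitrogen, such as butyl, would give a step beyond the scatter. They also leave open what a chain ending in an amine or a carboxylic acid would give there.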